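Acetyl for Methylsulfonyl: One Change on Two Cores

The source may report more compounds than this note shows. Statements on the series, on what has been measured and on what is new or still open speak of the compounds shown alone.

Three compounds sharing an amide-linked urea scaffold were tested in a functional assay on MV4-11 cells (Homo sapiens) for antiproliferative activity, with a stated time of 6 days, tested at 6.25 uM; a lower number here means a weaker effect, a higher number a stronger effect of the compound at the concentration tested. Compound 1 `CNC(=O)N1CCCc2ccc(NC(=O)c3ccc(-c4ccn(C(C)=O)n4)cc3)cc21` gives 91.4% and compound 2 `CNC(=O)N1CCCc2ccc(NC(=O)c3ccc(-c4ccn(S(C)(=O)=O)n4)cc3)cc21` gives 57.2%. The two differ only by acetyl in place of methylsulfonyl on an aromatic nitrogen, and that change made a number 34.2 percentage points higher from compound 2 to compound 1 (beyond the scatter). Compound 3 `CNC(=O)N1CCCc2ccc(NC(=O)c3cccc(-c4cnn(S(C)(=O)=O)c4)c3)cc21`, which gives 18%, is built from the same atoms as compound 2 joined differently; how the two cores differ is not broken down here, and compound 3 stands lowest of the three.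

Compound 4 `CNC(=O)N1CCCc2ccc(NC(=O)c3cccc(-c4cnn(C(C)=O)c4)c3)cc21` has not yet been measured. It relates to compound 3 exactly as compound 1 relates to compound 2: acetyl in place of methylsulfonyl on an aromatic nitrogen. Read one bond further out, the change runs from 1-(methylsulfonyl)-1H-pyrazol-4-yl to 1-acetyl-1H-pyrazol-4-yl, whereas in the measured pair it ran from 1-(methylsulfonyl)-1H-pyrazol-3-yl to 1-acetyl-1H-pyrazol-3-yl, so it is the same change set on a different core. Among the measured compounds shown here, because the single measured instance of this change, a number 34.2 percentage points higher from compound 2 to compound 1 (beyond the scatter), was large and beyond the scatter, a gain of similar direction is expected for compound 4 in this assay, tempered by the lower starting point of compound 3 at 18% and by the fact that only one such step is known. The estimated step is a number 30 percentage points higher from compound 3 to compound 4 (beyond the scatter). Compound 4 is thus expected to give about 48%, most likely between 25% and 72%.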

Compound 4, a percentage reported as inhibition, at one concentration (the size of the read-out at that concentration, not a potency): 82%
For compound 4 the middle estimate is 34 percentage points below the measured one; the whole stated range lies below it.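

On the second core, acetyl in place of methylsulfonyl on an aromatic nitrogen gave a number 64 percentage points higher from compound 3 to compound 4 (beyond the scatter) in this assay, so the change carried over in direction, but not at one fixed size: the same change on two cores in this assay, a number 34.2 percentage points higher (beyond the scatter) from compound 2 to compound 1 and a number 64 percentage points higher (beyond the scatter) from compound 3 to compound 4, 29.8 percentage points apart, beyond the scatter of two such steps

Both known pairs therefore favour acetyl over methylsulfonyl, and neither goes against that direction, but two pairs on two cores establish no rule for the wider series, and the size of the step on one core did not fix its size on the other. The read-out also comes from a single concentration, so these steps describe how large the effect was at that concentration, not how potency changed, and nothing here explains why the step differs between the cores.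

The compounds shown leave open whether the gain belongs to acetyl in particular or would extend to a longer acyl chain such as propanoyl, or to a group of another kind, such as an amine or a carboxylic acid, on that aromatic nitrogen. They also leave open whether the same change would keep its direction on any core beyond these two, or how its size would vary there.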